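Replacing a Chain Carbon by Oxygen on the Core

A few compounds are considered here, and "the series" means these few. Any claim that something is new, unique, unknown or untested is made for them only; others in the source may bear on it.

Measured so far in a functional assay on CHO cells for positive allosteric modulation of metabotropic glutamate receptor 2 (Homo sapiens), read by GTPgammaS binding, with a stated time of 30 min; on this read-out higher numbers stand for an effect only at larger amounts of compound and lower numbers for an effect already at smaller amounts:
compound 1 `CCc1cnc2c(C#N)c(N3CCC(c4ccccc4)CC3)ccn12` gives 501 nM
compound 2 `CCc1nnc2c(C#N)c(N3CCC(c4ccccc4)CC3)ccn12` gives 696 nM
compound 3 `CCCc1nnc2c(C#N)c(N3CCC(c4ccccc4)CC3)ccn12` gives 299 nM

Compound 3 is set apart from compound 2 by a 2.3-fold lower number from compound 2 to compound 3 (0.37 log units; beyond the scatter), while compound 1 sits within the scatter of compound 3. Compound 4 `COCc1nnc2c(C#N)c(N3CCC(c4ccccc4)CC3)ccn12` differs from compound 3 by methoxy in place of ethyl on a saturated chain carbon bound to an aromatic carbon. Going by the values given here, the only measured step on this chain is a 2.3-fold lower number from compound 2 to compound 3 (0.37 log units; beyond the scatter), which lengthened it by one carbon; no measured step exchanges a carbon for an oxygen at this place, so the outcome is uncertain. The expected step is therefore a 1.3-fold higher number from compound 3 to compound 4 (0.13 log units; within the scatter), lying within the scatter. For compound 4 the estimate in this assay is 400 nM, with a range from 150 nM to 1200 nM.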

Compound 4, half-maximal effective concentration: 468 nM
The estimate for compound 4 lay 1.2-fold (0.07 log units) below the measured number, within the range that was stated.
By their numbers in this assay, from the lowest: compounds 3, 4, 1 and 2 (each within the scatter of the next, the first and the last beyond it).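

Methoxy in place of ethyl gives a 1.6-fold higher number from compound 3 to compound 4 (0.19 log units; within the scatter) in this assay, so a chain carbon at this place can be an oxygen with no change that stands out from the scatter. Methoxy in place of methyl gives a 1.5-fold lower number from compound 2 to compound 4 (0.17 log units; within the scatter) as well, so the methoxy compound lies within the scatter of both, even though a 2.3-fold lower number from compound 2 to compound 3 (0.37 log units; beyond the scatter) sets those two apart. Nothing at hand gives a reason for this result.

Still open, as far as these compounds go, is how an amine in place of the methoxy, or a longer chain such as butyl, would fare at this place.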